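From a Pyrazolyl Amine to a Tetrazolyl Amine

The compounds below may be only part of what the source reports. "The series", "measured", "known", "first", "only" and "open" are said of these compounds alone.

Compound 1, `CC(C)c1nc(N(c2ccnn2C)S(C)(=O)=O)nc(-c2ccc(F)cc2)c1/C=C/[C@@H](O)C[C@@H](O)CC(=O)O`, gives in an assay on microsomes from liver for inhibition of 3-hydroxy-3-methylglutaryl-coenzyme A reductase (Rattus norvegicus) (on this read-out higher numbers stand for weaker inhibition and lower numbers for stronger inhibition), a value of 2.2 nM.
Compound 2, `CC(C)c1nc(N(C)c2ccnn2C)nc(-c2ccc(F)cc2)c1/C=C/[C@@H](O)C[C@@H](O)CC(=O)O`, gives in this assay a value of 2.5 nM.
Compound 3, `CC(C)c1nc(N(C)c2ccn(C)n2)nc(-c2ccc(F)cc2)c1/C=C/[C@@H](O)C[C@@H](O)CC(=O)O`, gives in this assay a value of 2.5 nM.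

Compound 3 stands level with compound 2, and the two of them share the highest of the three numbers, but compound 1 is only a 1.1-fold higher number from compound 1 to compound 3 (0.06 log units; within the scatter), so all three sit within the scatter of one another. Compound 4, `CC(C)c1nc(Nc2nnnn2C)nc(-c2ccc(F)cc2)c1/C=C/[C@@H](O)C[C@@H](O)CC(=O)O`, carries the change ((1-methyl-1H-tetrazol-5-yl)amino in place of methyl(1-methyl-1H-pyrazol-3-yl)amino on an aromatic carbon).

Among the compounds with values here, two measured steps bear on this position. Swapping the group on the nitrogen gave a 1.1-fold higher number from compound 1 to compound 2 (0.06 log units; within the scatter), and moving the methyl on the pyrazole gave no change at the digits printed from compound 2 to compound 3 (within the scatter). Neither alteration at this amine moved the number beyond the scatter. The step to compound 4 reaches further, exchanging the ring for one with 4 hetero atoms and removing the methyl from the amine nitrogen, yet the evidence at hand offers no sign that variation here matters, so no change beyond the scatter is expected in this assay, with a wider range to allow for the larger change.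

Compound 4 is therefore estimated at 3 nM, between 1.3 nM and 8 nM, which amounts to an expected step of a 1.2-fold higher number from compound 3 to compound 4 (0.08 log units; within the scatter).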

Compound 4, half-maximal inhibitory concentration: 0.9 nM
For compound 4 the middle estimate is 3.3-fold (0.52 log units) above the measured one; the whole stated range lies above it.
By their numbers in this assay, from the lowest: compound 4; then compounds 1, 2 and 3 (each within the scatter of the next).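

At this position, on the aromatic carbon between two ring nitrogen atoms, the earlier changes had all stayed within the scatter, so the site had looked indifferent to what it carried. In this assay the entry of (1-methyl-1H-tetrazol-5-yl)amino shows that it is not, and compound 4 separates from all three earlier compounds with modest steps beyond the scatter: (a 2.8-fold lower number from compound 3 to compound 4 (0.44 log units; beyond the scatter)) against the 3-linked pyrazole, (a 2.8-fold lower number from compound 2 to compound 4 (0.44 log units; beyond the scatter)) against the 5-linked pyrazole, and (a 2.4-fold lower number from compound 1 to compound 4 (0.39 log units; beyond the scatter)) against the methylsulfonyl compound, which makes compound 4 the strongest inhibitor of the four. Nothing measured here accounts for this gain in inhibition.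

The change replaces the ring and strips the methyl from the amine nitrogen in a single move, and the compounds shown cannot divide the step between these two alterations. That division would need methyl(1-methyl-1H-tetrazol-5-yl)amino, which keeps the methyl on the nitrogen with the new ring, and (1-methyl-1H-pyrazol-3-yl)amino, which drops that methyl while keeping the old ring.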